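A few compounds are considered here, and "the series" means these few. Any claim that something is new, unique, unknown or untested is made for them only; others in the source may bear on it.

Compound 3 `C=CCN(c1ccc(Cl)cc1C)S(=O)(=O)c1cc(Cl)ccc1Cl` belongs to a small set of sulfonamides tested in an ADME assay on A549 cells (Homo sapiens) for cytotoxicity, read by MTT assay; a lower number here means that less compound is tolerated, a higher number that more compound is tolerated. In this assay compound 3 gives > 5000 nM, which is a limit of the assay rather than a measured number. Compound 1 `C=CCN(c1ccccc1C)S(=O)(=O)c1cc(Cl)ccc1Cl` likewise gives > 5000 nM, again only a limit. Compound 2 `CCN(c1ccccc1C#N)S(=O)(=O)c1cc(Cl)ccc1Cl` gives > 5000 nM, also a limit. Among the measured compounds shown here, the one step between measured compounds, a step that the two limits leave unreadable from compound 1 to compound 3, therefore cannot be read. So compound 3 stands where every measured compound stands, at the limit of > 5000 nM in this assay, at which 3 of the 3 values shown sit.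

Compound 4 `Cc1cc(Cl)ccc1N(CC1CC1)S(=O)(=O)c1cc(Cl)ccc1Cl` differs from compound 3 by cyclopropyl in place of vinyl on a saturated chain carbon bound to a sulfonamide nitrogen. For the measured compounds named here, no measured step touches this change, and the only evidence in hand is the limit of > 5000 nM in this assay, at which 3 of the 3 values shown sit, so no step beyond the scatter is expected in this assay in either direction. The step this estimate means, a step that the limit leaves unreadable from compound 3 to compound 4, is expected to be small. Compound 4 is expected to give 10000 nM in this assay, within a range from 5000 nM to 30000 nM, most likely again reported as a limit.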

Compound 4, half-maximal cytotoxic concentration: > 5000 nM
Compound 4: a limit, no number (the forecaster's own chance of this, stated with the estimate: 85%); the middle value does not contradict the limit.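

No step can be read between compound 3 and compound 4: each gives only a limit in this assay, not a number. The compounds shown leave open at what concentration any of them harms these cells, and whether changing their groups shifts that concentration.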